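The source may hold more compounds than are shown below. What is called first, only, known or untested is meant among the compounds shown, and "the series" means these compounds.

Working notes on the series. Three compounds have numbers in a functional assay on MCF-10A cells (Homo sapiens) for cytotoxicity, read by sulforhodamine B assay, with a stated time of 2 days; on this read-out higher numbers stand for weaker inhibition and lower numbers for stronger inhibition. Compound 1 `CN(C)c1ccc(-c2nc3c(s2)C(O)CCC3)c(CO)c1` carries a hydroxymethyl on the aryl ring; in this assay compound 1 gives > 100000 nM, which is a limit of the assay and not a number. Compound 3 `CN(C)c1ccc(-c2nc3c(s2)C(O)CNC3)c(CO)c1`, with a ring nitrogen in the saturated part of the core, gives in this assay 70000 nM, a weak reading. Compound 2 `Cc1cc(N(C)C)ccc1-c1nc2c(s1)[C@H](O)CCC2` is the methyl-bearing analogue. In this assay compound 2 gives > 100000 nM, again a limit and not a number. Among the measured compounds shown here, compound 2 thus stands at the limit of > 100000 nM in this assay, at which 2 of the 3 values shown sit, so it has no exact value from which a step could be measured, and compound 3 is the only member with a finite reading.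

The unmeasured compound 4 `Cc1cc(N(C)C)ccc1-c1nc2c(s1)[C@@H](O)CCC2` differs from compound 2 as follows: the two compounds have the same atoms and bonds and differ only in configuration as drawn: 1 of 1 stereo elements differ; a stereocentre at a saturated ring carbon is drawn R in compound 2 and S in compound 4. For the measured compounds named here, no measured pair shows what such a change of configuration does in this assay, so no direction can be taken from the data. The expectation is that the step of a number no higher from compound 2 to compound 4 (the limit leaves the size open) stays within the scatter. Compound 4 is therefore expected to give about 100000 nM in this assay, with a range from 50000 nM to 200000 nM, most probably reported once more as a limit rather than a number.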

Compound 4, half-maximal inhibitory concentration: > 100000 nM
Compound 4 gave a limit, no number; the forecaster's own chance of this, stated with the estimate: 75%; the middle value sits exactly at the limit.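

In this assay compound 4 gives > 100000 nM, a limit and not a number. Compound 2 also stands at a limit, so no step can be read between compound 2 and compound 4. The compounds shown leave open whether the configuration at the saturated ring carbon changes the reading in this assay at all.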